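The source may report more compounds than this note shows. Statements on the series, on what has been measured and on what is new or still open speak of the compounds shown alone.

Compound 1 `CC(Nc1nc(N)nc2ccc(-c3cnn(C4CCNCC4)c3)cc12)c1c(Cl)ccc(F)c1Cl` gives 2230 nM in a functional assay on MCF7 cells (Homo sapiens) for antiproliferative activity, read by MTT assay, with a stated time of 72 h; a higher number here means a weaker inhibitor, a lower number a stronger inhibitor. Compound 2 `CC(Oc1ncnc2ccc(-c3cnn(C4CCNCC4)c3)cc12)c1c(Cl)ccc(F)c1Cl` gives 2670 nM in this assay. Compound 3 `CC(Nc1nc(N)nc2ccc(-c3cnn(C)c3)cc12)c1c(Cl)ccc(F)c1Cl` gives 2870 nM in this assay.

Compound 3 differs from compound 1 by methyl in place of piperidin-4-yl on an aromatic nitrogen; the step from this change is a 1.3-fold higher number from compound 1 to compound 3 (0.11 log units; within the scatter). Compound 2 carries a different core from compound 1, and the difference between the two cores is not broken down here; the two values themselves sit close together.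

Compound 4 `CC(Oc1ncnc2ccc(-c3cnn(C)c3)cc12)c1c(Cl)ccc(F)c1Cl` is not yet measured. It differs from compound 2 by methyl in place of piperidin-4-yl on an aromatic nitrogen. Its place line reads the same word for word as that of the change from compound 1 to compound 3, so it is the same change made on the core of compound 2.

Because the step of a 1.3-fold higher number from compound 1 to compound 3 (0.11 log units; within the scatter) stayed within the scatter, the same change on compound 2 is expected to do likewise, and the expected step is a 1.2-fold higher number from compound 2 to compound 4 (0.09 log units; within the scatter). Compound 4 is therefore estimated at 3300 nM in this assay, with the expected range running from 1700 nM to 6500 nM.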

Compound 4, half-maximal inhibitory concentration: 22600 nM
Estimate against measurement, compound 4: 6.8-fold (0.84 log units) below; the whole stated range lies below it.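

In this assay, the change from piperidin-4-yl to methyl on the aromatic nitrogen gives an 8.5-fold higher number from compound 2 to compound 4 (0.93 log units; beyond the scatter), so on the core of compound 2 this change has a clear effect on the number. Set beside the earlier step, the same change does not carry over in size from one core to the other: the same change on two cores in this assay, a 1.3-fold higher number (0.11 log units; within the scatter) from compound 1 to compound 3 and an 8.5-fold higher number (0.93 log units; beyond the scatter) from compound 2 to compound 4, 6.6-fold (0.82 log units) apart, beyond the scatter of two such steps This rests on one pair of compounds per core, and it does not show which feature of the two cores separates the steps, nor whether either step is typical of other cores in the series.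

The compounds shown leave open whether the piperidin-4-yl ring itself matters on the core of compound 2, or whether another group on the same aromatic nitrogen, such as an open-chain amine or a hydroxyethyl chain, would keep the number near that of compound 2, at 2670 nM. On these data alone, how the change from piperidin-4-yl to methyl would behave on any third core also remains open.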